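This account rests on a few compounds, and the source may have more. Where it says the series, first, only, none or still open, it means among the compounds named here.

Measured so far in an assay on isolated protein for inhibition of Dopamine beta-hydroxylase (Homo sapiens); a lower number here means a stronger inhibitor, a higher number a weaker inhibitor:
compound 1 `COc1ccc(Cn2cc[nH]c2=S)cc1` gives 204000 nM
compound 2 `COc1ccc(Cn2cc[nH]c2=S)cc1OC` gives 339000 nM

Compound 1 holds the lowest of the two numbers in this assay, with compound 2 nearest: a 1.7-fold higher number from compound 1 to compound 2 (0.22 log units; within the scatter). Compound 3 `S=c1[nH]ccn1Cc1ccc(Br)cc1` differs from compound 1 by bromo in place of methoxy on an aromatic carbon. Among the measured compounds shown here, no measured step exchanges one substituent for another on an aromatic carbon; the single measured step, a 1.7-fold higher number from compound 1 to compound 2 (0.22 log units; within the scatter), adds a methoxy group and stays within the scatter. There is thus no basis for expecting a step beyond the scatter in this assay in either direction. Compound 3 is estimated at 200000 nM, between 70000 nM and 600000 nM, an expected step of a 1.0-fold lower number from compound 1 to compound 3 (0.01 log units; within the scatter).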

Compound 3, half-maximal inhibitory concentration: 115000 nM
Compound 3: the middle estimate sits 1.7-fold (0.24 log units) above what was measured; low and high end bracket the measured number.
By their numbers in this assay, from the lowest: compounds 3, 1 and 2 (each within the scatter of the next, the first and the last beyond it).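

Exchanging one substituent for another on this aromatic carbon, para to a group of 7 heavy atoms, gives in this assay a 1.8-fold lower number from compound 1 to compound 3 (0.25 log units; within the scatter). Bromo can therefore stand in place of methoxy, and the hydrogen-bond acceptor leaves with it, without a step beyond the scatter, something the earlier addition of a methoxy group could not show. Nothing at hand bears on the reason for this result. From the compounds shown here alone, whether an amine or a carboxylic acid at this position would give a step beyond the scatter stays open. So does the effect of a longer chain in place of methoxy.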